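This account rests on a few compounds, and the source may have more. Where it says the series, first, only, none or still open, it means among the compounds named here.

Measured so far:
compound 1 `CC1CCN(C2CCN(S(=O)(=O)c3ccc(-c4ccccc4)cc3)CC2)CC1` — 258 nM
compound 2 `CC1CCN(C2CCN(S(=O)(=O)c3cccc(-c4ccccc4C(F)(F)F)c3)CC2)CC1` — 10 nM

The two compounds measured in a functional assay on DLD-1 cells (Homo sapiens) for antiproliferative activity, read by CellTiter-Glo, with a stated time of 72 h (a higher number here means a weaker inhibitor, a lower number a stronger inhibitor), share the same core and differ in the aryl sulfonyl part. Compound 1 gives 258 nM; compound 2 gives 10 nM. On these two numbers compound 1 stands highest, and its gap to compound 2 is well beyond the scatter. Compound 2 differs from compound 1 in more than one place, so nothing is drawn from that pair about any single change.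

Compound 3 `CCCCOc1ccc(S(=O)(=O)N2CCC(N3CCC(C)CC3)CC2)cc1` is not yet measured. It differs from compound 1 by butoxy in place of phenyl on an aromatic carbon. Going by the values given here, no measured pair isolates this change, so there is no reference step for it. A flexible chain of similar length stands where an aromatic ring stood; how this assay treats such a swap cannot be read from the two numbers available. The expectation is a step of modest size, likely upward, but not far beyond the scatter. The expected step is a 1.7-fold higher number from compound 1 to compound 3 (0.24 log units; within the scatter). Compound 3 is therefore estimated at 450 nM, with a range from 110 nM to 1800 nM.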

Compound 3, half-maximal inhibitory concentration: 2300 nM
Estimate against measurement, compound 3: 5.1-fold (0.71 log units) below, and the stated range ends below it.
By their numbers in this assay, from the lowest: compound 2; then compound 1; then compound 3.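

Butoxy in place of phenyl on this aromatic carbon, para to a large group, gives an 8.9-fold higher number from compound 1 to compound 3 (0.95 log units; beyond the scatter) in this assay, the only single-place step in the series so far. The position is therefore not indifferent to what it carries: an open chain with one hydrogen-bond acceptor does not stand in for a six-membered aromatic ring of carbon only, and the loss lies beyond the scatter. The step swaps the ring and brings in the oxygen at once, so it cannot assign the loss to either, and nothing measured here offers an explanation for its size.

An all-carbon pentyl chain on the same carbon would separate the loss of the ring from the entry of the oxygen, while a benzyloxy group would show whether an aromatic ring can be kept at the end of an oxygen-linked chain. Going by these compounds, a pyridine or a cyclohexyl ring in place of phenyl remains open as well, as does whether the step carries over to the aryl arrangement of compound 2.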